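Moving the Fluorine Pattern: Compound 3 Before Measurement

This account rests on a few compounds, and the source may have more. Where it says the series, first, only, none or still open, it means among the compounds named here.

Going by the values given here, compound 2 `COc1cc(C(=O)N/N=C/c2ccccc2F)cc(OC)c1OC` gives 76.5% in a functional assay on BGC-823 cells (Homo sapiens) for antiproliferative activity, read by MTT assay, tested at 5 uM (on this read-out higher numbers stand for a stronger effect at the one concentration tested and lower numbers for a weaker effect), the higher of the two numbers so far; compound 1 `COc1cc(C(=O)N/N=C/c2ccccc2C(F)(F)F)cc(OC)c1OC` gives 35.6%. Among the compounds with values here, the one measured step, a number 40.9 percentage points higher from compound 1 to compound 2 (beyond the scatter), concerns a different exchange and does not speak to the change at hand. Compound 3 `COc1cc(C(=O)N/N=C/c2ccc(F)c(F)c2)cc(OC)c1OC` differs from compound 2 by 3,4-difluorophenyl in place of 2-fluorophenyl on a carbon with a double bond to nitrogen. Within the data shown here, with no measured step bearing on this change, no shift beyond the scatter is expected, though the uncertainty is wide: the expected step is a number 14.5 percentage points lower from compound 2 to compound 3 (beyond the scatter). Compound 3 is therefore estimated at 62%, in a range from 30% to 88%.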

Compound 3, a percentage reported as inhibition, at one concentration (the size of the read-out at that concentration, not a potency): 51.9%
Compound 3: middle estimate off by 10.1 percentage points, on the high side; the measured number falls inside the stated range.
By their numbers in this assay, from the lowest: compound 1; then compound 3; then compound 2.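

In this assay, 3,4-difluorophenyl in place of 2-fluorophenyl on a carbon with a double bond to nitrogen gives a number 24.6 percentage points lower from compound 2 to compound 3 (beyond the scatter) and the read-out falls. This shows that the number at this position depends on the fluorine pattern of the aromatic ring, and not only on whether fluoro or trifluoromethyl is present. Nothing available explains this step. The compounds shown leave open how an amine or a nitrile on that ring would compare with fluoro. They also leave open whether a longer chain could replace the ring.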